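The source may report more compounds than this note shows. Statements on the series, on what has been measured and on what is new or still open speak of the compounds shown alone.

Of the compounds shown here, two have been measured in an assay on isolated protein for inhibition of Calpain-1 catalytic subunit (Homo sapiens); a lower number here means a stronger inhibitor, a higher number a weaker inhibitor. Compound 1 `CCC(NC(=O)C(CC(C)C)NC(=O)OCc1ccccc1)C(=O)C(=O)NCc1nc2c(c(=O)n(C)c(=O)n2C)n1C` gives 32000 nM in this assay. Compound 2 `CCNC(=O)C(=O)C(CC)NC(=O)C(CC(C)C)NC(=O)c1ccc2ccccc2n1` gives 500 nM in this assay, the lower of the two numbers, and the gap from it up to compound 1 lies well beyond the usual scatter of repeated measurements. Compound 3 `CCNC(=O)C(=O)C(CC)NC(=O)C(CC(C)C)NC(=O)N1CCOCC1` has not yet been measured. It keeps the shared core of compound 2 and differs in a single place: morpholin-4-yl in place of quinolin-2-yl on a carbonyl carbon. In plain words, the two-ring aromatic cap is exchanged for a six-membered non-aromatic ring with two hetero atoms, attached through the same carbonyl carbon. Among the compounds with values here, no measured pair shows this exchange, so its effect cannot be read from the numbers, and only the size of the structural change offers a guide. A step of modest size toward a higher number is expected, that is a 3.0-fold higher number from compound 2 to compound 3 (0.48 log units; beyond the scatter), somewhat beyond the scatter but not a change of class. Compound 3 is therefore expected to give about 1500 nM in this assay, within a range from 400 nM to 6000 nM.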

Compound 3, inhibition constant: 7900 nM
For compound 3 the middle estimate is 5.3-fold (0.72 log units) below the measured one; the whole stated range lies below it.
By their numbers in this assay, from the lowest: compound 2; then compound 3; then compound 1.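

In this assay, putting morpholin-4-yl in place of quinolin-2-yl on a carbonyl carbon, with the rest of the molecule unchanged, brings a 16-fold higher number from compound 2 to compound 3 (1.20 log units; beyond the scatter) and so shows that the group at this place has a large bearing on the inhibition constant. Compound 1 and compound 2 differ in more than one place, so their gap could not tie any effect to this position, whereas this single exchange does. The exchange swaps two rings, one of them all carbon, for one non-aromatic ring and goes from 10 heavy atoms to 6, while the counts of hydrogen-bond donors and acceptors stay the same on both sides, and no measurement here explains the loss.

Ring count, aromatic character, size and the atom joined to the carbonyl carbon all change together in this one step, so the compounds shown cannot say which of them matters. Going by these compounds, a phenyl group at the same place, or a piperidin-1-yl ring, would change fewer of these at once, and how either would fare remains open.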